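A Sulfanyl Swap on a Small Fused Core

The compounds below may be only part of what the source reports. "The series", "measured", "known", "first", "only" and "open" are said of these compounds alone.

Three compounds were measured in a functional assay (Homo sapiens) for inhibition of Nucleic Acid, tested at 100 uM; a lower number here means less inhibition, a higher number more inhibition at the concentration tested (going by the name of the read-out). Compound 1 `OC[C@H]1OC(n2cnc3c(SCc4ccccc4)nccc32)[C@H](O)[C@@H]1O` gives 30%. Compound 2 `CN(C)c1nccc2c1ncn2[C@H]1C[C@H](O)[C@@H](CO)O1` gives 0%. Compound 3 `CNc1[nH]ccc2ncnc1-2` gives 18%, the second highest of the three numbers; its nearest neighbour is compound 1, whose number lies higher by an amount beyond the usual scatter, and its furthest is compound 2, whose number lies lower, also beyond the scatter.

The next compound, compound 4 `Sc1[nH]ccc2ncnc1-2`, is compound 3 with a single change: sulfanyl in place of methylamino on an aromatic carbon. Going by the values given here, no measured pair shows this exchange on its own, so the data give no size for it. Compound 1 and compound 3 differ in more than one place, so the gap between their two values cannot be read as the effect of this change. The writer expects a step no larger than the scatter, a number 2 percentage points higher from compound 3 to compound 4 (within the scatter), with no settled direction. Compound 4 is accordingly estimated at 20%, within a range from 5% to 40%.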

Compound 4, a percentage reported as inhibition, at one concentration (the size of the read-out at that concentration, not a potency): 26%
The estimate for compound 4 lay 6 percentage points below the measured number; the measured number falls inside the stated range.
By their numbers in this assay, from the lowest: compound 2; then compounds 3, 4 and 1 (each within the scatter of the next, the first and the last beyond it).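

In this assay, the exchange of methylamino for sulfanyl on an aromatic carbon next to the ring nitrogen now has a size of its own, a number 8 percentage points higher from compound 3 to compound 4 (within the scatter). The two groups differ by one heavy atom and keep the same count of hydrogen-bond donors and acceptors, and at this position the exchange moves the read-out by no more than repeated measurements would. This holds for this single pair on this small core, and nothing shown explains why the two groups read alike.

As far as these compounds go, whether a primary amine, a methoxy group or a carboxylic acid on the same carbon would also stay within the scatter of compound 3 remains open. So does whether the exchange would give a similar step on the larger frameworks of compound 1 and compound 2.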